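Oxadiazolone Side Chain: Hydroxy Exchanged for Aminomethyl

The source may hold more compounds than are shown below. What is called first, only, known or untested is meant among the compounds shown, and "the series" means these compounds.

In a functional assay on the whole organism (strain Wistar albino) for inhibition, with Rattus norvegicus as the target, read by paw edema, with stated times of 30 min and 3 h, at a dose of 10 mg/kg by the oral route (on this read-out lower numbers stand for less inhibition and higher numbers for more inhibition at the one dose given (going by the name of the read-out)), compound 2 `COc1ccc(F)cc1-c1cccc(-c2nn(CCO)c(=O)o2)c1` gives 75%. Going by the values given here, its only measured neighbour, compound 1 `COc1ccc(F)cc1-c1cccc(-c2n[nH]c(=O)o2)c1`, gives 71% in this assay, and the step of a number 4 percentage points higher from compound 1 to compound 2 (within the scatter) lies within the scatter, so compound 2 stands level with compound 1 rather than apart from it. Compound 3 `COc1ccc(F)cc1-c1cccc(-c2nn(CCCN)c(=O)o2)c1` differs from compound 2 by aminomethyl in place of hydroxy on a saturated chain carbon, two bonds along the chain from an aromatic nitrogen. Among the compounds with values here, the one measured step touches the same chain on the aromatic nitrogen and was small, so no shift beyond the scatter is expected, a number 1 percentage points lower from compound 2 to compound 3 (within the scatter). Compound 3 is therefore estimated at 74%, with a range from 62% to 84%.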

Compound 3, a percentage reported as inhibition, in the whole organism at one dose (the size of the read-out at that dose, not a potency): 77%
The estimate for compound 3 lay 3 percentage points below the measured number, and the stated range covers the measured number.
By their numbers in this assay, from the lowest: compounds 1, 2 and 3 (each within the scatter of the next).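

In this assay, aminomethyl in place of hydroxy on this chain gives a step within the scatter (a number 2 percentage points higher from compound 2 to compound 3 (within the scatter)), so a terminal amine and a terminal alcohol cannot be told apart here. Set against hydrogen on the aromatic nitrogen, the 3-aminopropyl chain also stays within the scatter (a number 6 percentage points higher from compound 1 to compound 3 (within the scatter)), as the 2-hydroxyethyl chain did. No evidence is available that bears on this result. Going by these compounds, whether a carboxylic acid at the chain end, or a chain longer than 3-aminopropyl, would give a step beyond the scatter remains open.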